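This account rests on a few compounds, and the source may have more. Where it says the series, first, only, none or still open, it means among the compounds named here.

Working notes on the series. Three compounds share one core: compound 1 `Cc1ccc(CN2C(=O)S/C(=C\c3ccc(N(C)C)cc3)C2=O)cc1`, compound 2 `COc1ccc(/C=C2\SC(=O)N(Cc3ccc(C)cc3)C2=O)cc1` and compound 3 `Cc1ccc(CN2C(=O)S/C(=C\c3ccc(O)cc3)C2=O)cc1`. In a functional assay on the whole organism (plasma) with Mus musculus as the target, with a stated time of 15 days, at a dose of 10 mg/kg by the oral route (a lower number here means a weaker effect, a higher number a stronger effect of the compound at the dose given), compound 1 gives 14.9%, compound 2 gives 20.6% and compound 3 gives 19.9%. Compound 3 sits close to both neighbours: its nearest is compound 2, with a number 0.7 percentage points lower from compound 2 to compound 3 (within the scatter), its furthest compound 1, with a number 5 percentage points higher from compound 1 to compound 3 (within the scatter), and the remaining pair shows a number 5.7 percentage points higher from compound 1 to compound 2 (within the scatter). All three steps exchange a group on an aromatic carbon of the same ring, and none leaves the scatter.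

Compound 4 `Cc1ccc(CN2C(=O)S/C(=C\c3cccc(Br)c3)C2=O)cc1` is not yet measured. Its change from compound 3 is 3-bromophenyl in place of 4-hydroxyphenyl on a double-bonded chain carbon bound to a double-bonded ring carbon. Within the data shown here, the steps that bear on it are the three above, each a change on that same ring, each within the scatter. The expectation is therefore no step beyond the scatter, a number 1.9 percentage points lower from compound 3 to compound 4 (within the scatter), for compound 4 in this assay. Compound 4 is estimated at 18%, in a range from 7% to 30%, because compound 3 gives 19.9% and its neighbours lie within the scatter of it.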

Compound 4, a percentage reported as activity, at one dose (the size of the read-out at that dose, not a potency): 21.3%
Compound 4: middle estimate off by 3.3 percentage points, on the low side; low and high end bracket the measured number.
By their numbers in this assay, from the lowest: compounds 1, 3, 2 and 4 (each within the scatter of the next).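

The earlier steps shown here changed only the group carried on the aromatic ring, whereas this change also replaces 4-hydroxyphenyl or 4-methoxyphenyl with 3-bromophenyl, on a double-bonded chain carbon bound to a double-bonded ring carbon. In this assay, the exchange for 4-hydroxyphenyl shows a number 1.4 percentage points higher from compound 3 to compound 4 (within the scatter), and the exchange for 4-methoxyphenyl shows a number 0.7 percentage points higher from compound 2 to compound 4 (within the scatter). This position therefore accepts a group with 0 hydrogen-bond donors and 0 hydrogen-bond acceptors without a step beyond the scatter, and no measurement available here accounts for that result.

Open, from the compounds shown here alone, is whether a carboxylic acid or an aliphatic amine at this position, in place of the aromatic group, would give a step beyond the scatter. Also open, going by these compounds, is whether a longer chain elsewhere on the shared core would do so.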